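Compound 2 to compound 3: relocating the methoxyphenyl substitution

A few compounds are considered here, and "the series" means these few. Any claim that something is new, unique, unknown or untested is made for them only; others in the source may bear on it.

Of the compounds shown here, two sharing one core have been measured so far in a functional assay on HepG2 cells (Homo sapiens) for inhibition, read by MTT assay, with a stated time of 72 h; a higher number here means a weaker inhibitor, a lower number a stronger inhibitor. Compound 1 `CCCc1ccc(NC(=O)C2CCN(C/C=C/c3ccccc3)CC2)cc1` gives 9410 nM and compound 2 `COc1cccc(NC(=O)C2CCN(C/C=C/c3ccccc3)CC2)c1` gives 78600 nM as the higher of the two numbers, which makes compound 2 the weaker inhibitor of the pair. Among the compounds with values here, the one measured step is an 8.4-fold higher number from compound 1 to compound 2 (0.92 log units; beyond the scatter) and it came with 3-methoxyphenyl in place of 4-propylphenyl on an amide-type nitrogen.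

Compound 3 `COc1ccccc1NC(=O)C1CCN(C/C=C/c2ccccc2)CC1` keeps the shared core, and its change from compound 2 is 2-methoxyphenyl in place of 3-methoxyphenyl on an amide-type nitrogen in which 2-methoxyphenyl takes the place of 3-methoxyphenyl on the same amide-type nitrogen. Within the data shown here, the measured step bears on this only indirectly, for no measured pair compares two methoxyphenyl groups. A change smaller than an 8.4-fold higher number from compound 1 to compound 2 (0.92 log units; beyond the scatter) is therefore expected, with a slight lean towards a lower number. The expected change is a 1.6-fold lower number from compound 2 to compound 3 (0.20 log units; within the scatter) and this remains only an estimate. In this assay the estimate for compound 3 is 50000 nM with an expected range between 15000 nM and 160000 nM for now.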

Compound 3, half-maximal inhibitory concentration: 91200 nM
Compound 3: middle estimate off by 1.8-fold (0.26 log units), on the low side, within the range that was stated.
By their numbers in this assay, from the lowest: compound 1; then compounds 2 and 3 (each within the scatter of the next).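

Placing the methoxy group differently on the phenyl ring, with 2-methoxyphenyl in place of 3-methoxyphenyl on the amide-type nitrogen, gives the first comparison of two methoxyphenyl groups (a 1.2-fold higher number from compound 2 to compound 3 (0.06 log units; within the scatter)), and in this assay this change cannot be told apart from the scatter. The step from 4-propylphenyl to 2-methoxyphenyl (a 9.7-fold higher number from compound 1 to compound 3 (0.99 log units; beyond the scatter)) lies beyond the scatter, as does the step from 4-propylphenyl to 3-methoxyphenyl (an 8.4-fold higher number from compound 1 to compound 2 (0.92 log units; beyond the scatter)), so the gap to the 4-propylphenyl compound holds for both methoxyphenyl groups shown. Nothing available gives a reason for either the gap or the lack of one between the two methoxyphenyl groups.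

The compounds shown leave open whether that gap follows the propyl chain itself or the place it occupies on the ring, a question that 4-methoxyphenyl or 3-propylphenyl on the same nitrogen would address. They also leave open how a shorter or longer chain, such as 4-ethylphenyl or 4-butylphenyl, or a ring bearing an amine or a carboxylic acid, would read in this assay.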